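A few compounds are considered here, and "the series" means these few. Any claim that something is new, unique, unknown or untested is made for them only; others in the source may bear on it.

Working notes on the series. Within the data shown here, compound 3 `CC(C)N(O)C(=O)NCc1ncc(-c2cc(Cl)cc(F)c2-c2nnn(C)n2)cc1F` gives 1 nM in a functional assay on IMR-90 cells for antagonist activity at B1 bradykinin receptor (Homo sapiens), read by calcium flux (a lower number here means a stronger inhibitor, a higher number a weaker inhibitor), the lowest of the three numbers so far. Compound 1 `Cc1nc(-c2c(F)cc(Cl)cc2-c2cnc([C@@H](C)NC(=O)N(C)O)c(C)c2)no1` gives 3.6 nM in this assay, and compound 2 `CCN(O)C(=O)NCc1ncc(-c2cc(Cl)cc(F)c2-c2nnn(C)n2)cc1F` gives 4.6 nM. Among the measured compounds shown here, the one single-point step among the measured compounds runs a 4.6-fold lower number from compound 2 to compound 3 (0.66 log units; beyond the scatter), a change that enlarges the group on the amide-type nitrogen. Compound 4 `Cn1nnc(-c2c(F)cc(Cl)cc2-c2cnc(CNC(=O)N(O)C3CCCC3)c(F)c2)n1` carries the change (cyclopentyl in place of isopropyl on an amide-type nitrogen), again a larger group on that same nitrogen. For the measured compounds named here, only the step from compound 2 to compound 3 bears on it, so a further lowering in this assay is expected, though smaller and possibly within the scatter, as the new group is a ring rather than a chain. Compound 4 is therefore estimated at 0.7 nM, range 0.3 nM to 2 nM, a step of a 1.4-fold lower number from compound 3 to compound 4 (0.15 log units; within the scatter).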

Compound 4, half-maximal inhibitory concentration: 0.8 nM
Estimate against measurement, compound 4: 1.1-fold (0.06 log units) below; measured number inside the range.
By their numbers in this assay, from the lowest: compounds 4 and 3 (each within the scatter of the next); then compounds 1 and 2 (each within the scatter of the next).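

In this assay the change from isopropyl to cyclopentyl on the amide-type nitrogen gives a 1.3-fold lower number from compound 3 to compound 4 (0.10 log units; within the scatter) and so leaves the number unresolved from that of compound 3, showing that this nitrogen accepts a five-membered carbon ring. The step of a 5.8-fold lower number from compound 2 to compound 4 (0.76 log units; beyond the scatter) keeps the lowering over ethyl, but the lowering seen from ethyl to isopropyl does not continue beyond the scatter. No evidence on hand accounts for this result. As far as these compounds go, whether cyclohexyl or tetrahydropyranyl on this nitrogen would hold the number remains open, as does whether cyclopentyl would do so on the core of compound 1.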